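A few compounds are considered here, and "the series" means these few. Any claim that something is new, unique, unknown or untested is made for them only; others in the source may bear on it.

Within the data shown here, in a functional assay on NCI-H460 cells (Homo sapiens) for cytotoxicity, read by MTT assay, with a stated time of 68 h (a higher number here means a weaker inhibitor, a lower number a stronger inhibitor), compound 1, `COc1ccc(-c2cccc(NC(=O)C(Cl)Cl)c2)cc1`, gives 43300 nM, the only true number in this small series. Compound 2, `O=C(Nc1cccc(-c2ccc(F)cc2)c1)C(Cl)Cl`, reports only a limit of the assay, > 50000 nM. Compound 3, `O=C(Nc1cccc(-c2ccc(Cl)cc2)c1)C(Cl)Cl`, also reports only a limit, > 50000 nM. Compound 3 therefore stands at the limit of > 50000 nM in this assay, at which 2 of the 3 values shown sit.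

Compound 4, `COC(=O)c1ccc(-c2cccc(NC(=O)C(Cl)Cl)c2)cc1`, differs from compound 3 by methoxycarbonyl in place of chloro on an aromatic carbon, para to a large group: methoxycarbonyl in place of chloro on an aromatic carbon.

Three measured steps change the group at this place. Fluoro in place of methoxy gives an at least 1.1-fold higher number from compound 1 to compound 2 (0.06 log units; that floor lies within the scatter). Chloro in place of methoxy gives an at least 1.1-fold higher number from compound 1 to compound 3 (0.06 log units; that floor lies within the scatter). Chloro in place of fluoro gives a step that the two limits leave unreadable from compound 2 to compound 3. None of these steps involves methoxycarbonyl, so the series offers only a loose guide to the new group, and two of the three compounds give no exact number.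

Going by an at least 1.1-fold higher number from compound 1 to compound 3 (0.06 log units; that floor lies within the scatter), no step beyond the scatter is expected in this assay, and a reading at the limit would be no surprise. The expected change is an at least 1.1-fold lower number from compound 3 to compound 4 (0.04 log units; that floor lies within the scatter). For compound 4 the estimated value is 45000 nM, with an expected range from 22000 nM to 80000 nM.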

Compound 4, half-maximal inhibitory concentration: > 50000 nM
Compound 4: no number, only a limit; the forecaster's own chance of this, stated with the estimate: 50%; at least 1.1-fold (0.04 log units) between middle value and limit.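

Methoxycarbonyl is larger than fluoro or chloro and brings hydrogen-bond acceptors to this place, para to a large group, yet in this assay compound 4 also gives only a limit, > 50000 nM. Methoxycarbonyl in place of methoxy gives an at least 1.1-fold higher number from compound 1 to compound 4 (0.06 log units; that floor lies within the scatter), while the steps that join compound 4 to compound 2 and compound 3 cannot be read. The new result therefore extends the same picture to a quite different group, and the series stays crowded at the top of the range: the limit of > 50000 nM in this assay, at which 3 of the 4 values shown sit.

The limits hide how far compound 2, compound 3 and compound 4 really lie from one another, so these compounds cannot rank the groups at this place. Among these compounds, whether an amine, a carboxylic acid or a longer chain at this place would give a clearly lower number than the one seen for compound 1, 43300 nM, remains open.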